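Adding a Second Methoxy Group to a Weak Cytotoxic Scaffold

A few compounds are considered here, and "the series" means these few. Any claim that something is new, unique, unknown or untested is made for them only; others in the source may bear on it.

The measured compounds:
compound 1, `COc1cccc(CNc2ncnc3c2ncn3C2CCCCO2)c1`: 61000 nM
compound 2, `COc1ccc(CNc2ncnc3c2ncn3C2CCCCO2)cc1`: > 100000 nM
compound 3, `COc1ccc(CNc2ncnc3c2ncn3C2CCCCO2)c(OC)c1`: > 25000 nM

All three were tested in an ADME assay on K562 cells (Homo sapiens) for cytotoxicity, with a stated time of 72 h; a higher number here means a weaker inhibitor, a lower number a stronger inhibitor. Among the measured compounds shown here, compound 1 gives 61000 nM, the only plain number among them. For compound 2 the assay reports only a limit, > 100000 nM. For compound 3 the result is also only a limit, > 25000 nM.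

Compound 1 and compound 2 are built from the same atoms joined differently: 3-methoxyphenyl in place of 4-methoxyphenyl on a saturated chain carbon bound to a nitrogen on an aromatic ring. In the other direction this gives an at least 1.6-fold higher number from compound 1 to compound 2 (0.21 log units; that floor lies within the scatter). From compound 2 to compound 3 the change is methoxy in place of hydrogen on an aromatic carbon, which yields a step that the two limits leave unreadable from compound 2 to compound 3; the size cannot be read because the limit of > 100000 nM in this assay, at which 1 of the 3 values shown sits, and the limit of > 25000 nM in this assay, at which 1 of the 3 values shown sits, bound both ends.

Compound 4, `COc1cc(CNc2ncnc3c2ncn3C2CCCCO2)cc(OC)c1`, has not been measured. It differs from compound 1 by methoxy in place of hydrogen on an aromatic carbon. This is the same kind of change as that from compound 2 to compound 3, but not the same: in compound 3 the entering methoxy sits ortho to a large group, in compound 4 it sits meta to a large group, while in both it is meta to a methoxy group.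

The earlier step gave no readable size, and compound 1 stands at 61000 nM. Compound 4 is therefore expected to give about 80000 nM, somewhere from 30000 nM to 200000 nM. The expected step is a 1.3-fold higher number from compound 1 to compound 4 (0.12 log units; within the scatter), placed beside the unreadable a step that the two limits leave unreadable from compound 2 to compound 3.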

Compound 4, half-maximal inhibitory concentration: > 100000 nM
Compound 4 ended at the assay's limit; the forecaster's own chance of this, stated with the estimate: 50%; middle value at least 1.2-fold (0.09 log units) away from the limit.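

Methoxy in place of hydrogen on an aromatic carbon, meta to a large group and meta to a methoxy group, gives an at least 1.6-fold higher number from compound 1 to compound 4 (0.21 log units; that floor lies within the scatter). Going by these compounds, this figure is only a floor, and the true size of the step stays unknown, because compound 4 ended at a limit of the assay rather than at a number: the limit of > 100000 nM in this assay, at which 2 of the 4 values shown sit. The same kind of change from compound 2 to compound 3 cannot be read, and the methoxy enters at a different place there, so the data neither show that the change carries from one core to the other nor show that it fails to.

The compounds shown leave open whether any group on this aromatic ring can bring the number in this assay down to a clearly stronger level, since every compound here carries only methoxy groups on that ring and only compound 1 gives a plain number. An amine or a carboxylic acid in place of a methoxy group, or a longer chain in place of the single carbon that links the ring to the nitrogen, remains an open case.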